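Furan in place of hydroxyphenyl on the hydrazone carbon

The source may hold more compounds than are shown below. What is called first, only, known or untested is meant among the compounds shown, and "the series" means these compounds.

Compound 1 `CC1=CC[C@H](C(C)(C)NC(=S)N/N=C/c2ccc(O)cc2)CC1`: in a functional assay on UACC-62 cells (Homo sapiens) for inhibition, read by sulforhodamine B assay, with a stated time of 48 h (on this read-out lower numbers stand for stronger inhibition of growth and higher numbers for weaker inhibition of growth), compound 1 gives > 100000 nM, a limit of the assay.
Compound 2 `CC1=CC[C@H](C(C)(C)NC(=S)N/N=C/c2ccc(N(C)C)cc2)CC1`: in this assay compound 2 gives > 100000 nM, also a limit.
Compound 3 `COc1cc(/C=N/NC(=S)NC(C)(C)[C@H]2CC=C(C)CC2)ccc1O`: in this assay compound 3 gives 42300 nM.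

Compound 1 stands at the limit of > 100000 nM in this assay, at which 2 of the 3 values shown sit, so only a limit and no number is known for it. Compound 4 `CC1=CC[C@H](C(C)(C)NC(=S)N/N=C/c2ccco2)CC1` differs from it in one place: furan-2-yl in place of 4-hydroxyphenyl on a carbon with a double bond to nitrogen.

Two measured steps start from compound 1. The step that the two limits leave unreadable from compound 1 to compound 2 is the exchange of one substituent on the aromatic ring for another and yields no readable size. The step of an at least 2.3-fold lower number from compound 1 to compound 3 (0.37 log units; beyond the scatter) adds a methoxy group to the same ring and is at least modest. Neither step removes the six-membered ring or replaces it by a five-membered one, so neither bears directly on the change to compound 4; they show only that small edits on this ring move the read-out within a narrow band near the limit.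

No step beyond the scatter is therefore expected in this assay for compound 4, in either direction. Compound 4 is estimated at 90000 nM, with a range from 30000 nM to 300000 nM. This estimate corresponds to an at least 1.1-fold lower number from compound 1 to compound 4 (0.04 log units; that floor lies within the scatter).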

Compound 4, concentration for total growth inhibition: 14100 nM
Beside the measured number, compound 4's estimate is 6.4-fold (0.81 log units) above it, and the stated range ends above it.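

In this assay, furan-2-yl in place of 4-hydroxyphenyl on a carbon with a double bond to nitrogen gives an at least 7.0-fold lower number from compound 1 to compound 4 (0.85 log units; beyond the scatter), which shows that this position accepts exchange of the whole aromatic group and not only edits to substituents on the six-membered aromatic ring. The entering group has 0 hydrogen-bond donors, so a hydrogen-bond donor on this group is not required for a measurable value in this series. Compound 2, which also lacks the hydroxy, remains a limit at > 100000 nM, so removing the hydroxy does not by itself give a measurable value, and the read-out of compound 4 is tied to the furan-2-yl group as a whole.

The true size of the step stays open, since the value of compound 1 is only a limit: the limit of > 100000 nM in this assay, at which 2 of the 4 values shown sit.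

As far as these compounds go, whether the ring oxygen of furan-2-yl matters also stays open, and thiophen-2-yl, with sulfur in that ring, or an unsubstituted phenyl on the same carbon would separate the effect of the oxygen from that of ring size.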